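The source may report more compounds than this note shows. Statements on the series, on what has been measured and on what is new or still open speak of the compounds shown alone.

Compound 1, `CC(C)CCOc1cccc2occ(Cc3coc4ccccc4c3=O)c(=O)c12`: in a functional assay on HCT-15 cells (Homo sapiens) for antiproliferative activity, read by XTT assay (a higher number here means a weaker inhibitor, a lower number a stronger inhibitor), compound 1 gives > 10000 nM, a limit of the assay.
Compound 2, `O=c1c(Cc2coc3cccc(O)c3c2=O)coc2ccccc12`: in this assay compound 2 gives > 10000 nM, again a limit of the assay.
Compound 3, `O=c1c(Cc2coc3cccc(OCc4ccccc4)c3c2=O)coc2ccccc12`: in this assay compound 3 gives > 10000 nM, also a limit of the assay.

Compound 3 therefore stands with the other two at the limit of > 10000 nM in this assay, at which 3 of the 3 values shown sit, and no number separates any of the three. The steps among the measured compounds, a step that the two limits leave unreadable from compound 1 to compound 2, a step that the two limits leave unreadable from compound 1 to compound 3 and a step that the two limits leave unreadable from compound 2 to compound 3, all run between limits and cannot be sized.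

The unmeasured compound 4, `COc1cccc2occ(Cc3coc4ccccc4c3=O)c(=O)c12`, is reached from compound 3 by the change (hydrogen in place of phenyl on a saturated chain carbon bound to an oxygen on an aromatic ring). Going by the values given here, the steps that bear on this change are those that alter the same substituent on the aromatic oxygen: a step that the two limits leave unreadable from compound 1 to compound 3 and a step that the two limits leave unreadable from compound 2 to compound 3. Both are of unreadable size, so no direction can be derived from them; what they do show is that hydrogen, isopentyl and benzyl at this oxygen all leave the compound at the limit in this assay.

Compound 4 is therefore expected to sit at or near that same limit, with an estimated step that the limit leaves unreadable from compound 3 to compound 4 that cannot be distinguished from none. The estimate for compound 4 in this assay is 20000 nM, within 5000 nM to 100000 nM, most probably reported again as a limit.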

Compound 4, half-maximal inhibitory concentration: 3430 nM
Compound 4: the middle estimate sits 5.8-fold (0.77 log units) above what was measured, and the stated range ends above it.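

The methyl on the aromatic oxygen gives the first readable result at this position in this assay, where the earlier compounds had shown no difference among substituents. Replacing the phenyl of benzyl with hydrogen, which turns benzyloxy into methoxy, gives an at least 2.9-fold lower number from compound 3 to compound 4 (0.46 log units; beyond the scatter); methyl in place of hydrogen on the oxygen gives an at least 2.9-fold lower number from compound 2 to compound 4 (0.46 log units; beyond the scatter), and hydrogen in place of isobutyl on the saturated chain carbon gives an at least 2.9-fold lower number from compound 1 to compound 4 (0.46 log units; beyond the scatter). The substituent on this oxygen therefore does matter in this assay, since among the four compounds only the methyl ether comes off the limit, while the hydrogen, isopentyl and benzyl compounds all remain there: the limit of > 10000 nM in this assay, at which 3 of the 4 values shown sit.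

On these data alone, these limits mean that the true size of the three new steps stays open and that the steps among compounds 1, 2 and 3 cannot be read. The compounds shown also leave open whether methyl is a narrow optimum or part of a wider range, as an ethyl or propyl ether on the same oxygen, or a chain ending in an amine, would show.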